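A few compounds are considered here, and "the series" means these few. Any claim that something is new, unique, unknown or untested is made for them only; others in the source may bear on it.

In an assay on isolated protein for inhibition of Apoptosis regulator Bcl-2 (Homo sapiens), read by fluorescence polarization, with stated times of 5 min and 10 min (a lower number here means a stronger inhibitor, a higher number a weaker inhibitor), compound 3 `CC(C)=CCCC1=CC[C@@H](C(=O)N(C)C)[C@H](c2ccccc2)C1` gives only a limit, > 23000 nM. Compound 1 `CON(C)C(=O)[C@H]1CC2=C(CCCC2(C)C)C[C@@H]1c1ccccc1` likewise returns a limit, > 23000 nM. Among the measured compounds shown here, compound 2 `CC(C)=CCCC1=CC[C@H](C(=O)N(C)O)[C@@H](c2ccccc2)C1`, by contrast, yields a number in this assay, 2100 nM; with no computed step between it and compound 3, the two values can only be set side by side. Compound 3 therefore stands at the limit of > 23000 nM in this assay, at which 2 of the 3 values shown sit. Compound 4 `COC(=O)CCNC(=O)[C@@H]1CC=C(CCC=C(C)C)C[C@H]1c1ccccc1` differs from compound 3 in one place: (2-(methoxycarbonyl)ethyl)amino in place of dimethylamino on a carbonyl carbon. Without a measured step of this kind to lean on, no shift beyond the usual scatter is expected from compound 3 to compound 4, though a readable number rather than a limit cannot be excluded. Compound 4 is expected to give about 20000 nM, between 6000 nM and 60000 nM. That expectation amounts to a step of an at least 1.1-fold lower number from compound 3 to compound 4 (0.06 log units; that floor lies within the scatter) judged to lie within the scatter.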

Compound 4, inhibition constant: > 23000 nM
Compound 4: a limit, no number; the forecaster's own chance of this, stated with the estimate: 55%; middle value at least 1.1-fold (0.06 log units) from the limit.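

Among the compounds shown here, compound 3 and compound 4 both give only a limit in this assay, and no step between them can be read. The compounds shown leave open whether (2-(methoxycarbonyl)ethyl)amino in place of dimethylamino on a carbonyl carbon shifts inhibition at all.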